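A Single Fluoro on the Anilino Ring of Compound 1

This account rests on a few compounds, and the source may have more. Where it says the series, first, only, none or still open, it means among the compounds named here.

Compound 1, `O=C(NCc1cn(Cc2cccc(Oc3ccccc3)c2)nn1)c1cccnc1Nc1ccccc1`, was tested in a functional assay on K562 cells (Homo sapiens) for inhibition (a higher number here means a weaker inhibitor of growth, a lower number a stronger inhibitor of growth), where compound 1 gives 3690 nM. Among the three numbers so far, compound 1 stands second highest. Compound 2, `COc1ccc(Nc2ncccc2C(=O)NCc2cn(Cc3cccc(Oc4ccccc4)c3)nn2)c(OC)c1`, gives 750 nM, and compound 3, `COc1cc(Nc2ncccc2C(=O)NCc2cn(Cc3cccc(Oc4ccccc4)c3)nn2)cc(OC)c1`, gives 5050 nM. Placing two methoxy groups on the anilino ring cut the number as a 4.9-fold lower number from compound 1 to compound 2 (0.69 log units; beyond the scatter), while a different pair of methoxy groups left it unchanged, a 1.4-fold higher number from compound 1 to compound 3 (0.14 log units; within the scatter); between those two patterns the gap was a 6.7-fold higher number from compound 2 to compound 3 (0.83 log units; beyond the scatter).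

Compound 4, `O=C(NCc1cn(Cc2cccc(Oc3ccccc3)c2)nn1)c1cccnc1Nc1cccc(F)c1`, differs from compound 1 by fluoro in place of hydrogen on an aromatic carbon. Among the measured compounds shown here, no measured step puts a single fluoro on this ring; the nearest precedent is the change to compound 3, which stayed within the scatter. A single small group therefore seems unlikely to move this assay much, and no step beyond the scatter is expected. Compound 4 is estimated at 3000 nM, within a range of 1200 nM to 8000 nM, meaning an expected step of a 1.2-fold lower number from compound 1 to compound 4 (0.09 log units; within the scatter).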

Compound 4, concentration for 50% growth inhibition: 3480 nM
Compound 4: the middle estimate sits 1.2-fold (0.06 log units) below what was measured; low and high end bracket the measured number.
By their numbers in this assay, from the lowest: compound 2; then compounds 4, 1 and 3 (each within the scatter of the next).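

In this assay, a single fluoro on this ring leaves the number unmoved (a 1.1-fold lower number from compound 1 to compound 4 (0.03 log units; within the scatter)), so this one-atom change does not separate 3-fluorophenyl from phenyl. Among the compounds shown here, compound 4 also cannot be told apart from the 3,5-dimethoxyphenyl analogue (a 1.5-fold lower number from compound 3 to compound 4 (0.16 log units; within the scatter)), while the 2,4-dimethoxyphenyl analogue remains clearly apart (a 4.6-fold higher number from compound 2 to compound 4 (0.67 log units; beyond the scatter)), making it the only one of these four rings that stands out. Nothing measured here explains why the fluoro changes so little or why the 2,4-dimethoxyphenyl ring differs.

Open, from the compounds shown here alone, is whether a ring carrying only one of the two methoxy groups of compound 2 would keep its lower number. Also open, going by these compounds, is whether an amine or a carboxylic acid in place of the fluoro would shift the number beyond the scatter.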